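The source may report more compounds than this note shows. Statements on the series, on what has been measured and on what is new or still open speak of the compounds shown alone.

Measured compounds:
Compound 1, `Cc1c(C2CC2)nc2ccc(-n3ccc(OCc4ccc(F)cc4)cc3=O)cn12`, in an assay on CHO cells for displacement of a labelled ligand from melanin-concentrating hormone receptor 1 (Rattus norvegicus), read by scintillation counting, with a stated time of 1 h; on this read-out higher numbers stand for weaker inhibition and lower numbers for stronger inhibition: 28 nM
Compound 2, `COCc1nc2ccc(-n3ccc(OCc4ccc(F)cc4)cc3=O)cn2c1C`, in this assay: > 1000 nM

Among the measured compounds shown here, compound 1 gives 28 nM in this assay and is the only compound with a proper number. Compound 2 gives a limit, > 1000 nM, not a number; it sits at the limit of > 1000 nM in this assay, at which 1 of the 2 values shown sits. The step between them is an at least 35-fold higher number from compound 1 to compound 2 (1.55 log units; beyond the scatter). The change in that step lies on the shared core; the outer arm that the present question concerns is the same in compound 1 and compound 2.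

Compound 3, `Cc1c(C2CC2)nc2ccc(-n3ccc(OCc4csc(C(F)(F)F)c4)cc3=O)cn12`, differs from compound 1 in that arm: 5-(trifluoromethyl)thiophen-3-yl in place of 4-fluorophenyl on a saturated chain carbon bound to an oxygen on an aromatic ring. No measured step touches this part of the molecule, so the one step shown, large as it is, does not bear directly on what to expect here; it only shows that the assay can resolve a sizeable loss. With nothing measured at the changed position, the expectation rests on compound 1 alone, allowing a moderate shift in either direction. Compound 3 is therefore estimated at 60 nM, within 15 nM to 250 nM. This corresponds to an expected step of a 2.1-fold higher number from compound 1 to compound 3 (0.33 log units; beyond the scatter).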

Compound 3, half-maximal inhibitory concentration: 15 nM
Compound 3: middle estimate off by 4.0-fold (0.60 log units), on the high side; low and high end bracket the measured number.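

Among the compounds shown here, this result is the first measured step at the outer arm, since the only earlier step lay on the shared core. In this assay, the exchange of 4-fluorophenyl for 5-(trifluoromethyl)thiophen-3-yl gives a 1.9-fold lower number from compound 1 to compound 3 (0.27 log units; within the scatter), so compound 1 and compound 3 cannot be told apart on this read-out, and this position on the saturated chain carbon bound to an oxygen on an aromatic ring accepts a five-membered aromatic ring with one hetero atom in place of a six-membered ring of carbon only, with a trifluoromethyl group in place of a single fluorine. Nothing measured here accounts for why these two different arms read alike.

The compounds shown leave open whether the thiophene ring or the trifluoromethyl group carries this result, which a plain thiophen-3-yl or a phenyl bearing trifluoromethyl would separate. They also leave open how the arm would respond to a ring bearing an amine or a carboxylic acid, or to a longer chain in place of the single carbon that links the ring to the oxygen.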